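Methyl for isopropyl on the shared core

The compounds below may be only part of what the source reports. "The series", "measured", "known", "first", "only" and "open" are said of these compounds alone.

Compound 3 (`COc1ccc(Cn2c(C(=O)O)c(CNCc3cccc(O)c3)c3ccc(C(C)C)cc32)cc1`) gives 9270 nM in a functional assay on Bel-7402 cells (Homo sapiens) for antiproliferative activity, read by MTT assay, with a stated time of 72 h; a lower number here means a stronger inhibitor, a higher number a weaker inhibitor. Compound 2 (`COc1ccc(Cn2c(C(=O)O)c(CNCc3cccc(OC)c3)c3ccc(C)cc32)cc1`) gives 9830 nM, within the scatter of compound 3. Compound 1 (`COc1ccc(Cn2c(C(=O)O)c(CNCc3cccc(O)c3)c3ccccc32)cc1`) gives only a limit of the assay, > 50000 nM.

Compound 4 (`COc1ccc(Cn2c(C(=O)O)c(CNCc3cccc(O)c3)c3ccc(C)cc32)cc1`) differs from compound 3 by methyl in place of isopropyl on an aromatic carbon. One measured step changes that same carbon: an at least 5.3-fold lower number from compound 1 to compound 3 (0.73 log units; beyond the scatter), with isopropyl in place of hydrogen. Compound 2 also carries methyl there, with methoxy where compound 4 has hydroxyl, and compound 2 gives 9830 nM. A small move towards a higher number is therefore expected in this assay, with a 1.6-fold higher number from compound 3 to compound 4 (0.21 log units; within the scatter) as the expected step. For compound 4 the estimate is 15000 nM, with an expected range of 7000 nM to 40000 nM.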

Compound 4, half-maximal inhibitory concentration: 19800 nM
The estimate for compound 4 lay 1.3-fold (0.12 log units) below the measured number; the range from low to high includes it.
By their numbers in this assay, from the lowest: compounds 3, 2 and 4 (each within the scatter of the next, the first and the last beyond it). At a limit, above all of these: compound 1.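

Methyl in place of hydrogen on this aromatic carbon already gives an at least 2.5-fold lower number from compound 1 to compound 4 (0.40 log units; beyond the scatter), so the gain seen with isopropyl is not confined to isopropyl. Methyl in place of isopropyl still gives a 2.1-fold higher number from compound 3 to compound 4 (0.33 log units; beyond the scatter), while the step of hydrogen in place of methyl on the oxygen, a 2.0-fold higher number from compound 2 to compound 4 (0.30 log units; within the scatter), is no clear change. Compound 1 holds a limit of the assay, so steps from it are bounds only: the limit of > 50000 nM in this assay, at which 1 of the 4 values shown sits.

On these data alone, whether ethyl, a longer chain or chlorine on this carbon would fit the same order remains open. Also open, as far as these compounds go, is whether a tert-butyl group there would give a lower number than isopropyl.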